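Trifluoromethylphenyl Replaces Chloro-Methoxyphenyl on the Pyrazole Core

The source may hold more compounds than are shown below. What is called first, only, known or untested is meant among the compounds shown, and "the series" means these compounds.

Measured compounds and their values in a functional assay on BJAB cells (Homo sapiens) for antiproliferative activity, with a stated time of 4 days; on this read-out higher numbers stand for an effect only at larger amounts of compound and lower numbers for an effect already at smaller amounts:
compound 1, `COc1ccc(-c2c(C)nn(-c3nc(-c4ccc(Cl)c(Cl)c4)c(SC(C)C)s3)c2C(=O)O)cc1`, 2100 nM;
compound 2, `Cc1nn(-c2nc(-c3ccc(Cl)c(Cl)c3)c(SC(C)C)s2)c(C(=O)O)c1-c1ccc(Cl)cc1`, 2500 nM;
compound 3, `COc1cc(Cl)cc(-c2c(C)nn(-c3nc(-c4ccc(Cl)c(Cl)c4)c(SC(C)C)s3)c2C(=O)O)c1`, 760 nM.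

Compound 3 gives the lowest of the three numbers; the nearest is compound 1, and compound 2 lies furthest away. The step of a 2.8-fold lower number from compound 1 to compound 3 (0.44 log units; beyond the scatter) and the step of a 3.3-fold lower number from compound 2 to compound 3 (0.52 log units; beyond the scatter) are both beyond the scatter, while the step of a 1.2-fold higher number from compound 1 to compound 2 (0.08 log units; within the scatter) stays within it.

Compound 4, `Cc1nn(-c2nc(-c3ccc(Cl)c(Cl)c3)c(SC(C)C)s2)c(C(=O)O)c1-c1ccc(C(F)(F)F)cc1`, is the next compound. Its structure differs from compound 3 in one place: 4-(trifluoromethyl)phenyl in place of 3-chloro-5-methoxyphenyl on an aromatic carbon.

The measured steps bear on this change in two ways. The steps from compound 1 and compound 2 to compound 3 show that replacing a 4-methoxyphenyl or a 4-chlorophenyl by the 3-chloro-5-methoxyphenyl lowered the number by a modest amount. For the measured compounds named here, compound 4 carries a 4-(trifluoromethyl)phenyl, closer in pattern to the rings of compound 1 and compound 2, and the step from compound 1 to compound 2 suggests that exchanging the single group on such a ring changes little. Compound 4 is therefore expected to return toward the numbers of compound 1 and compound 2, with the estimated step of a 2.6-fold higher number from compound 3 to compound 4 (0.42 log units; beyond the scatter) in the direction of a higher number. In this assay compound 4 is estimated at 2000 nM, within a range from 900 nM to 4500 nM.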

Compound 4, half-maximal effective concentration: 3500 nM
Compound 4: the middle estimate sits 1.8-fold (0.24 log units) below what was measured; the measured number falls inside the stated range.
By their numbers in this assay, from the lowest: compound 3; then compounds 1, 2 and 4 (each within the scatter of the next).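

In this assay, the 4-(trifluoromethyl)phenyl in place of 3-chloro-5-methoxyphenyl, on the aromatic carbon next to the ring atom that bears a carboxy group, gives a 4.6-fold higher number from compound 3 to compound 4 (0.66 log units; beyond the scatter), so the gain seen with compound 3 does not carry over to this ring. The other two comparisons, a 1.4-fold higher number from compound 2 to compound 4 (0.15 log units; within the scatter) and a 1.7-fold higher number from compound 1 to compound 4 (0.22 log units; within the scatter), both stay within the scatter, so trifluoromethyl, chloro and methoxy on the singly substituted phenyl cannot be told apart at this position, and among the four compounds only the 3-chloro-5-methoxyphenyl of compound 3 stands apart from the rest. Nothing measured here accounts for why that one ring behaves differently.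

The compounds shown leave open whether the lower number of compound 3 belongs to its chloro, to its methoxy or to the two together, since no phenyl here carries just one of them in the same placement. They also leave open how this position would respond to a ring bearing an amine, a hydroxyl or a longer alkyl chain such as butyl.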